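The compounds below may be only part of what the source reports. "The series", "measured", "known", "first", "only" and "open" are said of these compounds alone.

For the measured compounds named here, compound 2 `CC1=NC(c2cn(S(=O)(=O)c3ccccc3Cl)c3ccc(C)cc23)CN1` gives 1500 nM in an assay on isolated protein for inhibition of kallikrein-7 (Mus musculus), read by fluorescence, with stated times of 10 min and 30 min (a higher number here means a weaker inhibitor, a lower number a stronger inhibitor), and is the only compound with a number in this assay. Compound 1 `CC1=NC(c2cn(S(=O)(=O)c3ccc(Cl)cc3)c3ccc(C)cc23)CN1` gives > 100000 nM in this assay, which is a limit of the assay and not a number. Going by the values given here, the one measured step, an at least 66-fold lower number from compound 1 to compound 2 (1.82 log units; beyond the scatter), is large. Compound 3 `CC1=NC(c2cn(S(=O)(=O)c3ccccc3C#N)c3ccc(C)cc23)CN1` differs from compound 2 by cyano in place of chloro on an aromatic carbon. Among the compounds with values here, that step changes the group itself rather than its place, so no measured step bears on it directly, and a step within the usual scatter is expected, a 1.3-fold higher number from compound 2 to compound 3 (0.12 log units; within the scatter). Compound 3 is therefore estimated at 2000 nM, between 500 nM and 8000 nM.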

Compound 3, half-maximal inhibitory concentration: 11000 nM
The estimate for compound 3 lay 5.5-fold (0.74 log units) below the measured number; the whole stated range lies below it.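

Keeping the place and changing only the group also moves the number in this assay, so what sits on this aromatic carbon counts, not only where it sits: a 7.3-fold higher number from compound 2 to compound 3 (0.87 log units; beyond the scatter). The 2-cyanophenyl compound still stands clear of the 4-chlorophenyl one, with an at least 9.0-fold lower number from compound 1 to compound 3 (0.95 log units; beyond the scatter). Compound 1 is held at a limit of the assay and not a number: the limit of > 100000 nM in this assay, at which 1 of the 3 values shown sits.

On these data alone, whether methyl, methoxy or an amine at this place would give a lower number than compound 2 stays open. So does whether fluoro or bromo would track chloro here.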